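The source may hold more compounds than are shown below. What is called first, only, known or untested is meant among the compounds shown, and "the series" means these compounds.

Of the compounds shown here, two of a shared core have been measured in a functional assay on SK-BR-3 cells (Homo sapiens) for inhibition, read by MTT assay, with a stated time of 2 days, tested at 100 uM; on this read-out lower numbers stand for less inhibition of growth and higher numbers for more inhibition of growth at the one concentration tested. Compound 1, `CNC(=O)c1cc(Oc2ccc3nc(NC(=O)Nc4ccc(C5CCN(C(C)C)CC5)cc4)sc3c2)ccn1`, gives 91.6% in this assay. Compound 2, `CNC(=O)c1cc(Oc2ccc3nc(NC(=O)c4cccc(F)n4)sc3c2)ccn1`, gives 89.4% in this assay, which is the lower of the two numbers, though the gap to compound 1 lies within the scatter of repeated measurements. The next compound, compound 3, `CNC(=O)c1cc(Oc2ccc3nc(NC(=O)Nc4ccc(Br)cc4)sc3c2)ccn1`, has not yet been measured; it differs from compound 2 in one place: (4-bromophenyl)amino in place of 6-fluoropyridin-2-yl on a carbonyl carbon. No step between measured compounds with the same change has been recorded, so the expectation rests only on the two numbers shown. Since compound 1 with its 91.6% and compound 2 with its 89.4% both sit high in this assay, compound 3 is expected to stay close, with an estimated step of a number 1.4 percentage points lower from compound 2 to compound 3 (within the scatter), no larger than the scatter. The estimate for compound 3 in this assay is 88%, within a range from 74% to 97%.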

Compound 3, percent growth inhibition at one concentration: 69.2%
Compound 3: middle estimate off by 18.8 percentage points, on the high side; the whole stated range lies above it.
By their numbers in this assay, from the lowest: compound 3; then compounds 2 and 1 (each within the scatter of the next).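

On the carbonyl carbon of the shared core, (4-bromophenyl)amino in place of 6-fluoropyridin-2-yl is not a neutral exchange in this assay, with a number 20.2 percentage points lower from compound 2 to compound 3 (beyond the scatter), so this position does respond to what it carries. The carbamoyl link alone does not account for the lower number, since compound 1 carries that link as well, and bromo in place of 1-isopropylpiperidin-4-yl on an aromatic carbon gives a number 22.4 percentage points lower from compound 1 to compound 3 (beyond the scatter). No independent measurement accompanies these numbers to explain the steps.

The compounds shown leave open whether a smaller halogen such as chloro, or an amine such as dimethylamino, in place of bromo on that aromatic carbon would restore the higher number. They also leave open whether the lower number follows from the bromo itself or from the loss of 1-isopropylpiperidin-4-yl.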